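A few compounds are considered here, and "the series" means these few. Any claim that something is new, unique, unknown or untested is made for them only; others in the source may bear on it.

Compound 1 `O=C(CCCCCCNC(=O)C(O)(O)C(F)(F)F)Nc1ccc(Br)cc1` carries a seven-carbon chain bearing an anilide at one end and a hydrated trifluoromethyl ketone amide at the other. In an assay on isolated protein for inhibition of histone deacetylase 4 (Homo sapiens), read by chemiluminescence, with a stated time of 3 h (on this read-out lower numbers stand for stronger inhibition and higher numbers for weaker inhibition), compound 1 gives 2600000 nM, the highest of the two numbers recorded here. Within the data shown here, its only measured neighbour is compound 2 `O=C(CCCCCCNC(=O)C(O)(O)C(F)(F)F)Nc1ccc(-c2ccccc2)cc1`, which in this assay gives 1100000 nM; the change from compound 1 to compound 2 is a 2.4-fold lower number from compound 1 to compound 2 (0.37 log units; beyond the scatter), brought about by phenyl in place of bromo on an aromatic carbon. Compound 3 `O=C(CCCCCCNC(=O)C(O)(O)C(F)(F)F)Nc1nc2ccccc2s1` has not yet been measured. It differs from compound 1 by 1,3-benzothiazol-2-yl in place of 4-bromophenyl on an amide-type nitrogen. Among the measured compounds shown here, no measured step repeats this exact swap; the step from compound 1 to compound 2 only shows that reshaping the aryl end moves the number modestly. A step of similar modest size, towards a lower number, is therefore expected, giving a 1.7-fold lower number from compound 1 to compound 3 (0.24 log units; within the scatter). Compound 3 is estimated at 1500000 nM, within a range from 400000 nM to 6000000 nM.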

Compound 3, half-maximal inhibitory concentration: 430000 nM
Beside the measured number, compound 3's estimate is 3.5-fold (0.54 log units) above it; the range from low to high includes it.
By their numbers in this assay, from the lowest: compound 3; then compound 2; then compound 1.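

In this assay, the step to the fused ring group gives a 6.0-fold lower number from compound 1 to compound 3 (0.78 log units; beyond the scatter), so this amide-type nitrogen accepts a group with ring nitrogen and sulfur, and the number still falls. Compound 2 showed only a carbon-only aryl change, with a 2.4-fold lower number from compound 1 to compound 2 (0.37 log units; beyond the scatter); of the three compounds, compound 3 now has the lowest number, though at 430000 nM it remains a very weak inhibitor in absolute terms. No supporting measurement here explains why this swap lowers the number.

The compounds shown leave open which part of 1,3-benzothiazol-2-yl matters: the sulfur, the ring nitrogen or the fused benzene ring. Going by these compounds, a 1,3-benzoxazol-2-yl group, with oxygen in place of sulfur, or a plain thiazol-2-yl group would help separate these parts, and the effect of a longer chain also remains open.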